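Fluoro to Hydrogen on the Aryl Ring: Expected Effect on Dose

The source may report more compounds than this note shows. Statements on the series, on what has been measured and on what is new or still open speak of the compounds shown alone.

Measured compounds in a functional assay on the whole organism (strain NMRI) with Mus musculus as the target, with a stated time of 4 h; on this read-out higher numbers stand for an effect only at larger amounts of compound and lower numbers for an effect already at smaller amounts:
compound 1 `COc1ccc(Cn2cc(CO/N=C/c3c(-c4ccccc4)nc4c(C)cccn34)nn2)cc1`: 100 mg/kg
compound 2 `C#CCO/N=C/c1c(-c2ccc(F)cc2)nc2c(C)cccn12`: 100 mg/kg
compound 3 `COc1ccc(Cn2cc(CO/N=C/c3c(-c4ccc(F)cc4)nc4c(C)cccn34)nn2)cc1`: 40 mg/kg

Compound 1 and compound 2 sit level at the digits printed, within the scatter, while compound 3 needs a smaller dose than either. The change from compound 3 to compound 1, (hydrogen in place of fluoro on an aromatic carbon), gave a 2.5-fold higher number from compound 3 to compound 1 (0.40 log units; beyond the scatter), a modest step. The difference between the cores of compound 2 and compound 3 is not broken down here. Compound 4 `C#CCO/N=C/c1c(-c2ccccc2)nc2c(C)cccn12` arises from compound 2 by hydrogen in place of fluoro on an aromatic carbon, the same change at a place described in the same words. For the measured compounds named here, compound 4 is therefore expected to show a 1.6-fold higher number from compound 2 to compound 4 (0.20 log units; within the scatter), resting on the single earlier step of a 2.5-fold higher number from compound 3 to compound 1 (0.40 log units; beyond the scatter) and on compound 2 starting at 100 mg/kg. For compound 4 the estimate in this assay is 160 mg/kg, between 100 mg/kg and 300 mg/kg.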

Compound 4, minimum effective dose: 100 mg/kg
Estimate against measurement, compound 4: 1.6-fold (0.20 log units) above; measured number inside the range.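

In this assay, the change from 4-fluorophenyl to phenyl gave no change at the digits printed from compound 2 to compound 4 (within the scatter). Set beside the earlier step, this result does not differ from it by more than repeated measurements would allow: the same change on two cores in this assay, a 2.5-fold higher number (0.40 log units; beyond the scatter) from compound 3 to compound 1 and no change at the digits printed (within the scatter) from compound 2 to compound 4, 2.5-fold (0.40 log units) apart, within the scatter of two such steps. For the compounds shown here, the two steps therefore give no sign that the change behaves differently on the two cores, but they do not show that it carries over with a fixed size, since there are only two steps and only one lies beyond the scatter.

The compounds shown leave open how a chloro or a methoxy group would read at this place on the aromatic ring. They also leave open how the change would behave with an amine or a longer chain in place of the side chains shown.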